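Methyl in Place of Fluoro: An Expectation for Compound 4

A few compounds are considered here, and "the series" means these few. Any claim that something is new, unique, unknown or untested is made for them only; others in the source may bear on it.

Of the compounds shown here, three sharing one core have been measured. Compound 1 `O=C(/C=C/c1ccc2c(c1)B(O)OC2)c1ccc(F)cc1` gives 7600 nM in a toxicity assay on WI-38 cells (Homo sapiens) for cytotoxicity, read by MTT assay, with a stated time of 48 h; a lower number here means a stronger inhibitor, a higher number a weaker inhibitor. Compound 2 `Cc1ccc(C(=O)/C=C/c2ccc3c(c2)B(O)OC3)cc1` gives 22200 nM in this assay, and compound 3 `O=C(/C=C/c1ccc2c(c1)B(O)OC2)c1cccc(F)c1` gives 26700 nM. The change from compound 1 to compound 2 is methyl in place of fluoro on an aromatic carbon; it made a 2.9-fold higher number from compound 1 to compound 2 (0.47 log units; beyond the scatter). Compound 1 and compound 3 carry the same atoms joined differently, as 3-fluorophenyl in place of 4-fluorophenyl on a carbonyl carbon, and the step was a 3.5-fold higher number from compound 1 to compound 3 (0.55 log units; beyond the scatter). Between compound 2 and compound 3 the step was a 1.2-fold higher number from compound 2 to compound 3 (0.08 log units; within the scatter).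

Compound 4 `Cc1cccc(C(=O)/C=C/c2ccc3c(c2)B(O)OC3)c1` is not yet measured. It differs from compound 3 by methyl in place of fluoro on an aromatic carbon. This is the same kind of change as that from compound 1 to compound 2, but the place is not identical: there the methyl sits para to a large group, here meta to a large group. Because the earlier change gave a 2.9-fold higher number from compound 1 to compound 2 (0.47 log units; beyond the scatter), compound 4 is expected to give a higher number than compound 3, with an estimated step of a 1.9-fold higher number from compound 3 to compound 4 (0.27 log units; within the scatter), tempered by the different place. For compound 4 the estimate in this assay is 50000 nM, between 20000 nM and 120000 nM.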

Compound 4, half-maximal inhibitory concentration: 16700 nM
Beside the measured number, compound 4's estimate is 3.0-fold (0.48 log units) above it; measured number below the stated range.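

In this assay methyl in place of fluoro did not carry over from the 4-fluorophenyl compound to the 3-fluorophenyl compound with the same size, and the step on the second core was a 1.6-fold lower number from compound 3 to compound 4 (0.20 log units; within the scatter) and so lay within the scatter, while the two steps differ by more than the scatter: the same change on two cores in this assay, a 2.9-fold higher number (0.47 log units; beyond the scatter) from compound 1 to compound 2 and a 1.6-fold lower number (0.20 log units; within the scatter) from compound 3 to compound 4, 4.7-fold (0.67 log units) apart, beyond the scatter of two such steps. The shift from 4-methylphenyl to 3-methylphenyl gave a 1.3-fold lower number from compound 2 to compound 4 (0.12 log units; within the scatter) and the exchange of 4-fluorophenyl for 3-methylphenyl gave a 2.2-fold higher number from compound 1 to compound 4 (0.34 log units; beyond the scatter) so that compound 1 alone stands apart from the other three compounds. This shows that in this series the step measured on one core cannot simply be added on another, but with one pair on each core it does not show why the two steps differ or how the change would behave on any further core.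

The compounds shown leave open how a methoxy group, an amine or a carboxylic acid in the same place on the phenyl ring would stand in this assay. They also leave open whether any group other than the fluoro of compound 1 would give a similarly low number.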